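Swapping Thiophen-3-yl for Furan-3-yl: An Expectation

This account rests on a few compounds, and the source may have more. Where it says the series, first, only, none or still open, it means among the compounds named here.

Compound 2 `CNc1ncnc2c1c(-c1ccsc1)cn2[C@@H]1O[C@H](CO)[C@@H](O)[C@H]1O` was tested in a functional assay on HepG2 cells (Homo sapiens) for antiproliferative activity, read by XTT assay, with a stated time of 72 h; on this read-out higher numbers stand for weaker inhibition and lower numbers for stronger inhibition. In this assay compound 2 gives > 20000 nM, which is a limit of the assay and not a measured number. Compound 1 `Nc1nc(N)c2c(-c3ccoc3)cn([C@@H]3O[C@H](CO)[C@@H](O)[C@H]3O)c2n1` is built on a related framework with different groups on the shared core; in this assay compound 1 gives > 20000 nM, again a limit rather than a number. Both results therefore sit at the limit of > 20000 nM in this assay, at which 2 of the 2 values shown sit.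

Compound 3 `CNc1ncnc2c1c(-c1ccoc1)cn2[C@@H]1O[C@H](CO)[C@@H](O)[C@H]1O` has not yet been measured. It differs from compound 2 by furan-3-yl in place of thiophen-3-yl on an aromatic carbon. For the measured compounds named here, no step between two measured compounds is available, so the size of this change cannot be read from data. Since compound 2 sits at the limit with > 20000 nM, and compound 1, which also carries a furan-3-yl, sits at the limit too, compound 3 is expected to remain at the limit. The step that the limit leaves unreadable from compound 2 to compound 3 is expected to be none beyond the scatter. For compound 3 the estimate in this assay is 30000 nM, within 15000 nM to 100000 nM.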

Compound 3, half-maximal inhibitory concentration: > 20000 nM
Compound 3: only a limit was reported (the forecaster's own chance of this, stated with the estimate: 85%); the middle value does not contradict the limit.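

Compound 2 and compound 3 both stop at a limit of the assay rather than a number, so swapping thiophen-3-yl for furan-3-yl gives no readable step: the limit of > 20000 nM in this assay, at which 3 of the 3 values shown sit.

The compounds shown leave open whether these two groups differ at all, since none yields an actual number in this assay.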